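Working notes: from compound 2 to compound 3

The compounds below may be only part of what the source reports. "The series", "measured", "known", "first", "only" and "open" are said of these compounds alone.

Values in a functional assay on CCRF-CEM cells (Homo sapiens) for inhibition, read by MTT assay, with a stated time of 72 h (a higher number here means a weaker inhibitor, a lower number a stronger inhibitor), so far
- compound 1 `C=C(Br)C(=O)Nc1cccc(/C=C/C(=O)Nc2ccccc2)c1` gives 190 nM
- compound 2 `C=C(Br)C(=O)Nc1cccc(/C=C/C(=O)Nc2cccc(F)c2)c1` gives 26000 nM
- compound 3 `C=C(Br)C(=O)Nc1cccc(/C=C/C(=O)Nc2ccc(Cl)cc2)c1` awaits measurement

Compound 2 at 26000 nM holds the higher of the two numbers and is the weaker inhibitor here. The change at issue is 4-chlorophenyl in place of 3-fluorophenyl on an amide-type nitrogen in plain words 4-chlorophenyl in place of 3-fluorophenyl on an amide-type nitrogen. For the measured compounds named here, the one measured step bearing on it is a 140-fold higher number from compound 1 to compound 2 (2.14 log units; beyond the scatter) for fluoro in place of hydrogen on an aromatic carbon, which is large and beyond the scatter. Going by the values given here, compound 3 carries no fluoro, but no measured step covers 4-chlorophenyl, so only part of that large step is expected to reverse. A sizeable move to a lower number in this assay is expected, estimated as a 13-fold lower number from compound 2 to compound 3 (1.11 log units; beyond the scatter) at this stage. For compound 3 the expected value is 2000 nM within an estimated range from 200 nM to 15000 nM for now.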

Compound 3, half-maximal inhibitory concentration: 460 nM
Compound 3: the middle estimate sits 4.3-fold (0.64 log units) above what was measured; low and high end bracket the measured number.
By their numbers in this assay, from the lowest: compound 1; then compound 3; then compound 2.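

In this assay, the change to 4-chlorophenyl on the amide-type nitrogen gives a 57-fold lower number from compound 2 to compound 3 (1.75 log units; beyond the scatter), so a halogen on this phenyl does not by itself bring the large loss seen in compound 2. Measured against the unsubstituted phenyl, the chloro compound shows only a 2.4-fold higher number from compound 1 to compound 3 (0.38 log units; beyond the scatter), whereas the fluoro compound shows a 140-fold higher number from compound 1 to compound 2 (2.14 log units; beyond the scatter). This position therefore tolerates one halogenated phenyl far better than the other, and compound 1 still gives the lowest number of the three, with its steps to both others beyond the scatter.

From the compounds shown here alone, the step from 3-fluorophenyl to 4-chlorophenyl alters both the halogen and where it sits, so the share of each remains open, as does the reading for a phenyl bearing an amine or a carboxylic acid. Nothing available explains the gap between the two halogenated compounds.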